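Shortening a Side Arm: 2-Phenylethenyl Gives Way to Phenyl

This account rests on a few compounds, and the source may have more. Where it says the series, first, only, none or still open, it means among the compounds named here.

Compound 1, `COc1ccc(C(O)(C/C=C\c2ccccc2)c2cccc3ccccc23)c(OC)c1OC`, 19400 nM
Compound 2, `COc1ccc(C(c2ccc(OC(C)CN(C)C)cc2)c2cccc3ccccc23)c(OC)c1OC`, 15000 nM

In a functional assay on THP-1 cells (Homo sapiens) for inhibition, read by sulforhodamine B assay, with a stated time of 48 h (a lower number here means a stronger inhibitor, a higher number a weaker inhibitor), compound 1 gives 19400 nM, while compound 2 gives 15000 nM. The two numbers lie within the usual scatter of each other, so compound 1 and compound 2 cannot be told apart on this basis; both are weak inhibitors, and the two structures differ in so many places that their pair says nothing about any single change.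

Compound 3, `COc1ccc(C(O)(Cc2ccccc2)c2cccc3ccccc23)c(OC)c1OC`, is the untested member. It differs from compound 1 in one place: phenyl in place of 2-phenylethenyl on a saturated chain carbon, two bonds along the chain from two aromatic carbons and an oxygen on a saturated carbon. For the measured compounds named here, no measured pair in this set isolates a change of this kind, so there is no step to lean on. With both measured compounds sitting at weak inhibition and the change limited to shortening one side arm, the step from compound 1 to compound 3 is expected to be small, a 1.0-fold higher number from compound 1 to compound 3 (0.01 log units; within the scatter), not beyond the scatter in either direction. Compound 3 is therefore estimated at 20000 nM, with a range from 8000 nM to 50000 nM.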

Compound 3, half-maximal inhibitory concentration: 12400 nM
The estimate for compound 3 lay 1.6-fold (0.21 log units) above the measured number; measured number inside the range.
By their numbers in this assay, from the lowest: compounds 3, 2 and 1 (each within the scatter of the next).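

For the compounds shown here, this is the first comparison in the set that isolates a single place. In this assay, phenyl in place of 2-phenylethenyl on a saturated chain carbon, two bonds along the chain from two aromatic carbons and an oxygen on a saturated carbon, gives a 1.6-fold lower number from compound 1 to compound 3 (0.19 log units; within the scatter). The same change, read one bond further out as 3-phenylprop-2-en-1-yl to benzyl, thus takes the side arm from 8 heavy atoms to 6 and removes its double bond outside the aromatic ring while keeping the aromatic ring itself, and this leaves compound 1 and compound 3 indistinguishable in this measurement; no supporting data are available to explain that outcome.

Going by these compounds, the step changes length and the double bond together, so a saturated 3-phenylpropyl arm would be needed to separate the two, and whether a much smaller arm such as methyl would also leave the number within the scatter remains open. Also open, on these data alone, is whether a carboxylic acid or an amine carried on this side arm would move the number at this position at all.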